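A few compounds are considered here, and "the series" means these few. Any claim that something is new, unique, unknown or untested is made for them only; others in the source may bear on it.

Measured compounds:
- compound 1, `CCOC(=O)c1c(-c2ccccc2Cl)[nH]c2cc(OC)ccc2c1=O`: 28000 nM
- compound 2, `CCOC(=O)c1c(-c2ccc(C(C)(C)C)cc2)[nH]c2cccc(OC)c2c1=O`: 1000 nM
- compound 3, `CCOC(=O)c1c(-c2cccc(OC)c2)[nH]c2cccc(OC)c2c1=O`: > 100000 nM

These three compounds share one core and were tested in a physicochemical assay for solubility, in phosphate buffer, at pH 7.4; a higher number here means a more soluble compound, a lower number a less soluble compound. Compound 1 gives 28000 nM, which is the higher of the two plain numbers recorded in this assay. Compound 2 gives the lower one, 1000 nM, and the gap between compound 1 and compound 2 is well beyond the usual scatter. For compound 3 this assay reports only a limit, > 100000 nM, rather than a number (the limit of > 100000 nM in this assay, at which 1 of the 3 values shown sits).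

The next compound, compound 4, `CCOC(=O)c1c(-c2ccc(Cl)cc2)[nH]c2cc(OC)ccc2c1=O`, has not yet been measured in this assay. It is built from the same atoms as compound 1, joined differently: 4-chlorophenyl in place of 2-chlorophenyl on an aromatic carbon. In plain terms, the chlorine on the phenyl ring moves from the 2-position to the 4-position while everything else stays the same.

Among the compounds with values here, no measured pair here shows what this kind of repositioning does to solubility, so the expectation rests on compound 1 alone. The step from compound 1 to compound 4 is expected to be modest and downward, a 2.3-fold lower number from compound 1 to compound 4 (0.37 log units; beyond the scatter), but a result within the scatter would not be surprising. Compound 4 is therefore estimated at 12000 nM, with a likely range from 3000 nM to 50000 nM.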

Compound 4, solubility: 3000 nM
For compound 4 the middle estimate is 4.0-fold (0.60 log units) above the measured one; the measured number falls inside the stated range.
By their numbers in this assay, from the lowest: compound 2; then compound 4; then compound 1. At a limit, above all of these: compound 3.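

In this assay, moving the chlorine from 2-chlorophenyl to 4-chlorophenyl gives a 9.3-fold lower number from compound 1 to compound 4 (0.97 log units; beyond the scatter). Within the data shown here, this is the first comparison between compounds that differ in one place, and it shows that the number can shift beyond the scatter even though the atoms stay the same and only their arrangement on the phenyl ring changes. Nothing measured here accounts for the size or direction of this step, so the result records what happened without explaining it.

The compounds shown leave open whether this step depends on chlorine itself or would also appear with another group on the phenyl ring, such as a carboxylic acid or an amine in its place. Compound 2 and compound 3 differ from compound 1 and compound 4 in more than one place, so they cannot show whether the same repositioning would have a similar effect elsewhere in the series, and this single pair sets no general rule.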